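Writhing-test series: carboxy in place of hydroxymethyl

This account rests on a few compounds, and the source may have more. Where it says the series, first, only, none or still open, it means among the compounds named here.

Measured so far:
compound 1, `CC(C)C(=O)OC[C@H]1C[C@@H](Cl)C[C@@H](c2ccc3ccccc3c2)O1`, 44.4%
compound 2, `OC[C@H]1C[C@@H](Cl)C[C@@H](c2ccc3ccccc3c2)O1`, 46.6%

In a functional assay on the whole organism (Abdomen, strain Swiss albino) for inhibition, with Mus musculus as the target, in the writhing test, with a stated time of 30 min, at a dose of 30 mg/kg by the oral route (on this read-out lower numbers stand for less inhibition and higher numbers for more inhibition at the one dose given (going by the name of the read-out)), compound 2 gives 46.6%, and the step of a number 2.2 percentage points higher from compound 1 to compound 2 (within the scatter) lies within the scatter, so compound 2 and compound 1 stand side by side on the numbers shown. Compound 3, `O=C(O)[C@H]1C[C@@H](Cl)C[C@@H](c2ccc3ccccc3c2)O1`, differs from compound 2 by carboxy in place of hydroxymethyl on a saturated ring carbon. Among the measured compounds shown here, the one measured step, a number 2.2 percentage points higher from compound 1 to compound 2 (within the scatter), alters the same oxygen-bearing group and stays within the scatter; it does not match the new change directly, so the expectation rests on it loosely. Compound 3 is therefore expected to give 45%, a step of a number 1.6 percentage points lower from compound 2 to compound 3 (within the scatter), with a range of 25% to 65%.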

Compound 3, a percentage reported as inhibition, in the whole organism at one dose (the size of the read-out at that dose, not a potency): 28.1%
The estimate for compound 3 lay 16.9 percentage points above the measured number; the measured number falls inside the stated range.
By their numbers in this assay, from the lowest: compound 3; then compounds 1 and 2 (each within the scatter of the next).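

At the saturated ring carbon next to the ring oxygen, this assay now separates the groups: carboxy in place of hydroxymethyl gives a number 18.5 percentage points lower from compound 2 to compound 3 (beyond the scatter), and carboxy in place of ((isopropylcarbonyl)oxy)methyl gives a number 16.3 percentage points lower from compound 1 to compound 3 (beyond the scatter). The earlier pair showed no separation at this carbon, so the read-out does respond to the group placed there. No available data account for this drop.

Open, on these data alone, is how a methyl ester or a primary amide of the carboxy group would read here, and whether a longer chain ending in hydroxyl would match hydroxymethyl.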